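This account rests on a few compounds, and the source may have more. Where it says the series, first, only, none or still open, it means among the compounds named here.

Measured so far:
compound 1, `C=C(Br)C(=O)Nc1ccc(C(=O)/C=C/c2ccccc2)cc1`, 690 nM
compound 2, `C=C(Br)C(=O)Nc1ccc(C(=O)/C=C/c2cccc(OC)c2)cc1`, 1800 nM
compound 3, `C=C(Br)C(=O)Nc1ccc(C(=O)/C=C/c2ccc(N(C)C)cc2)cc1`, 2800 nM

In a functional assay on FM3A cells (Mus musculus) for antiproliferative activity, with a stated time of 48 h (on this read-out lower numbers stand for stronger inhibition and higher numbers for weaker inhibition), compound 1 gives the lowest number of the three measured compounds, that is, the strongest inhibition. The two measured steps both change the far aromatic ring and both weaken inhibition: a 2.6-fold higher number from compound 1 to compound 2 (0.42 log units; beyond the scatter) and a 4.1-fold higher number from compound 1 to compound 3 (0.61 log units; beyond the scatter).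

Compound 4, `Nc1ccc(C(=O)/C=C/c2ccccc2)cc1`, changes a different place. Compared with compound 1, the difference is hydrogen in place of (1-bromoethenyl)carbonyl on a nitrogen on an aromatic ring. Neither measured step touches this nitrogen or the group attached to it, so no measured step bears directly on this change, and the size and direction of its effect cannot be read from the shown data. For the measured compounds named here, the two measured steps show only that changes elsewhere on the shared core moved this assay by modest amounts.

Without a comparable step, a weaker number is expected for compound 4, with a wide range: an estimated step of a 5.1-fold higher number from compound 1 to compound 4 (0.71 log units; beyond the scatter), giving an estimate of 3500 nM, between 700 nM and 20000 nM.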

Compound 4, half-maximal inhibitory concentration: 34000 nM
The estimate for compound 4 lay 9.7-fold (0.99 log units) below the measured number; the measured number lies above the stated range.
By their numbers in this assay, from the lowest: compound 1; then compounds 2 and 3 (each within the scatter of the next); then compound 4.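

For the compounds shown here, the nitrogen on the aromatic ring is far more sensitive than anything the earlier compounds showed: in this assay, taking away the (1-bromoethenyl)carbonyl group and leaving a plain amino group gives a 49-fold higher number from compound 1 to compound 4 (1.69 log units; beyond the scatter). That step is much larger than the two earlier changes, a 2.6-fold higher number from compound 1 to compound 2 (0.42 log units; beyond the scatter) and a 4.1-fold higher number from compound 1 to compound 3 (0.61 log units; beyond the scatter), so the group on this nitrogen has the biggest effect on the number of any change seen so far. No measurement shown here explains why this change has so large an effect.

The compounds shown leave open which part of the lost group matters, whether the bromine, the double bond or the carbonyl. An acetyl group on this nitrogen, or an ethenylcarbonyl group without the bromine, would help separate these parts.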